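Trifluoromethyl in Place of Nitrile on a Shared Core

The compounds below may be only part of what the source reports. "The series", "measured", "known", "first", "only" and "open" are said of these compounds alone.

Compound 1 `Fc1ccccc1-c1ccc(Cn2nnc3ccccc32)cn1` was run in an ADME assay on microsomes from liver (Homo sapiens) for metabolic stability, tested at 2.5 uM (on this read-out lower numbers stand for slow clearance and higher numbers for fast clearance), and gives "not determined" (no result reported), and compound 3 `N#Cc1cccc2c1nnn2CC1CC1` in this assay likewise gives "not determined" (no result reported), so compound 3 stands without a number, and compound 1 is in the same position. Within the data shown here, the only number on the core shared by compounds 2, 3 and 4 comes from compound 2 `Clc1cccc2c1nnn2CC1CC1`, which in this assay gives 4.2 mL/min/g. Compound 4 `FC(F)(F)c1cccc2c1nnn2CC1CC1` differs from compound 3 in one place: trifluoromethyl in place of cyano on an aromatic carbon. Among the measured compounds shown here, no measured step connects these compounds, so nothing here shows in which direction such a change moves clearance, and a shift beyond the usual scatter can neither be expected nor ruled out. Compound 2, with its 4.2 mL/min/g, is the nearest reference point. Compound 4 is therefore expected to give about 5 mL/min/g in this assay, within a range from 2 mL/min/g to 12 mL/min/g.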

Compound 4, intrinsic clearance in a liver preparation (reported as CLH), per the amount of preparation that the assay uses: 0.3 mL/min/g
Compound 4: middle estimate off by 17-fold (1.22 log units), on the high side; measured number outside the range, below it.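

On the shared core, one swap on this aromatic carbon is enough to move the result in this assay strongly towards slow clearance: trifluoromethyl in place of chloro gives a 14-fold lower number from compound 2 to compound 4 (1.15 log units; beyond the scatter). Compound 3 has no number, so the swap from nitrile to trifluoromethyl itself cannot be read. Nothing available explains the drop. As far as these compounds go, whether a methoxy group or an amine at this position would give a number as low as that of compound 4 stays open. So does where nitrile falls relative to chloro and trifluoromethyl.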